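Swapping cyano for carboxy on a benzyl ether of an acetophenone core

The compounds below may be only part of what the source reports. "The series", "measured", "known", "first", "only" and "open" are said of these compounds alone.

Measured compounds in an assay on isolated protein for binding affinity to leukotriene B4 receptor 1 (Homo sapiens), tested at 1 uM; on this read-out higher numbers stand for more inhibition at the one concentration tested (going by the name of the read-out) and lower numbers for less inhibition:
- compound 1, `C=CCc1cc(C(C)=O)c(O)cc1OCCCCC`: 23%
- compound 2, `C=CCc1cc(C(C)=O)c(O)cc1OCc1ccc(C#N)cc1`: 28%
- compound 3, `CCc1cc(C(C)=O)c(O)cc1OCc1ccc(C#N)cc1`: 11%

Of the compounds shown here, three have been measured so far, all sharing the same core. Compound 3 gives 11% in this assay, the lowest of the three numbers. Its nearest neighbour is compound 1, and the furthest is compound 2; both gaps lie beyond the scatter. Going by the values given here, the only single-point step among the measured compounds runs from compound 2 to compound 3, where the change was a number 17 percentage points lower from compound 2 to compound 3 (beyond the scatter), a modest drop.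

The next compound, compound 4, `CCc1cc(C(C)=O)c(O)cc1OCc1ccc(C(=O)O)cc1`, differs from compound 3 in one place: carboxy in place of cyano on an aromatic carbon. Among the compounds with values here, none of the measured steps concerns this change; the one step on record alters a side chain on the core, not the group on the benzyl ring. There is therefore no direct guide to how replacing cyano with carboxy will move the number in this assay, and the expectation must rest on compound 3 alone.

With that in mind, compound 4 is expected to land near compound 3, with a step of a number 1 percentage points higher from compound 3 to compound 4 (within the scatter) that is estimated not to exceed the scatter. The estimate for compound 4 in this assay is 12%, within a range from 0% to 30%.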

Compound 4, a percentage reported as inhibition, at one concentration (the size of the read-out at that concentration, not a potency): 0%
For compound 4 the middle estimate is 12 percentage points above the measured one, within the range that was stated.
By their numbers in this assay, from the lowest: compound 4; then compound 3; then compounds 1 and 2 (each within the scatter of the next).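

In this assay, carboxy in place of cyano on an aromatic carbon para to a large group gives a number 11 percentage points lower from compound 3 to compound 4 (beyond the scatter). Going by these compounds alone, until now, the only single change on record was in the side chain on the shared core, so this step is the first to show that the read-out also responds to a change at this other site, with compound 4 at 0% in this series. Nothing measured here explains the drop, so the numbers record that it happens but not what lies behind it.

On these data alone, it remains open whether the loss belongs to carboxy alone or would also appear with other groups on this carbon, such as a methyl ester, a primary amide or an amine, and whether any of these would stay near compound 4 or come closer to compound 3. Also open, as far as these compounds go, is whether carboxy would give the same kind of step on the side chain of compound 2, which would show whether the two changes act independently of each other.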